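The source may report more compounds than this note shows. Statements on the series, on what has been measured and on what is new or still open speak of the compounds shown alone.

Measured so far:
compound 1, `CCNC(=O)c1cc(Oc2ccc(NC(=O)c3nn(-c4cccc(F)c4)c(=O)cc3C)cc2)ccn1`, 18900 nM
compound 2, `CNC(=O)c1cc(Oc2ccc(NC(=O)c3nn(-c4ccccc4Cl)c(=O)cc3C)cc2F)ccn1`, 136000 nM

Both compounds were tested in a functional assay on MCF7 cells (Homo sapiens) for antiproliferative activity, read by MTT assay, with a stated time of 72 h; a higher number here means a weaker inhibitor, a lower number a stronger inhibitor. Of the two numbers, compound 2 gives the higher one, 136000 nM, and the gap to compound 1, which gives 18900 nM, lies beyond the usual scatter, so compound 2 is the weaker of the pair. The two structures differ in several places at once, so no single change can be read from that gap.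

Compound 3, `CNC(=O)c1cc(Oc2ccc(NC(=O)c3nn(-c4cccc(C(F)(F)F)c4)c(=O)cc3C)cc2F)ccn1`, has not yet been tested. It is built from compound 2 with one change: 3-(trifluoromethyl)phenyl in place of 2-chlorophenyl on an aromatic nitrogen. Nothing measured here isolates what this swap does on its own. The expectation is a modest move toward a lower number, a 2.7-fold lower number from compound 2 to compound 3 (0.43 log units; beyond the scatter), though a result within the scatter of compound 2 would not be surprising. For compound 3 in this assay the estimate is 50000 nM, with a likely range from 15000 nM to 160000 nM.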

Compound 3, half-maximal inhibitory concentration: 45800 nM
Estimate against measurement, compound 3: 1.1-fold (0.04 log units) above, within the range that was stated.
By their numbers in this assay, from the lowest: compound 1; then compound 3; then compound 2.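

Among these compounds, compound 2 and compound 3 form the first pair that differs in only one place, so this assay can now be read for a single change: 3-(trifluoromethyl)phenyl in place of 2-chlorophenyl on the aromatic nitrogen gives a 3.0-fold lower number from compound 2 to compound 3 (0.47 log units; beyond the scatter), with the rest of the molecule unchanged. This shows that the number responds to the group on this nitrogen, although the step is modest. The swap alters both the substituent and its position on the phenyl ring, so the pair cannot separate the two, and no measurement offered here explains the step.

On these data alone, what a phenyl with no substituent would give at this nitrogen remains open. So does the effect of a phenyl carrying an amine or a carboxylic acid.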